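The source may report more compounds than this note shows. Statements on the series, on what has been measured and on what is new or still open speak of the compounds shown alone.

Of the compounds shown here, three that share one core have been measured in a functional assay on A549 cells (Homo sapiens) for antiproliferative activity, read by MTT assay, with a stated time of 72 h; a lower number here means a stronger inhibitor, a higher number a weaker inhibitor. There, compound 1 (`O=C(Nc1ccc(Nc2nccc(NC3CCCC3)n2)cc1)Nc1ccc(Cl)c(C(F)(F)F)c1`) gives 5880 nM, compound 2 (`O=C(Nc1ccc(Nc2nccc(Nc3ccc(Cl)cc3)n2)cc1)Nc1ccc(Cl)c(C(F)(F)F)c1`) gives 6320 nM and compound 3 (`O=C(Nc1ccc(Nc2nccc(NC3CCCC3)n2)cc1)NC1CCCCC1`) gives 5320 nM. Compound 3 therefore sits within the scatter of both other compounds, and the set shows no meaningful spread. Compound 4 (`O=C(Nc1ccc(Nc2nccc(NC3CCCC3)n2)cc1)Nc1cccc(C(F)(F)F)c1`) differs from compound 3 by 3-(trifluoromethyl)phenyl in place of cyclohexyl on an amide-type nitrogen. The step bearing most directly on this change acts at the same nitrogen: a 1.1-fold lower number from compound 1 to compound 3 (0.04 log units; within the scatter), with cyclohexyl replacing 4-chloro-3-(trifluoromethyl)phenyl. The other measured step, a 1.1-fold higher number from compound 1 to compound 2 (0.03 log units; within the scatter), places 4-chlorophenyl in place of cyclopentyl on a nitrogen on an aromatic ring, and it too stays within the scatter. Neither step points in a direction, so no shift beyond the scatter is expected in this assay. The expected change is a 1.0-fold higher number from compound 3 to compound 4 (0.01 log units; within the scatter). Compound 4 is estimated at 5500 nM, with an expected range from 3000 nM to 10000 nM.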

Compound 4, half-maximal inhibitory concentration: 4900 nM
Beside the measured number, compound 4's estimate is 1.1-fold (0.05 log units) above it, within the range that was stated.
By their numbers in this assay, from the lowest: compounds 4, 3, 1 and 2 (each within the scatter of the next).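

In this assay the amide-type nitrogen now carries a third group, and the step of a 1.1-fold lower number from compound 3 to compound 4 (0.04 log units; within the scatter) shows that 3-(trifluoromethyl)phenyl and cyclohexyl are not told apart at this place. The step of a 1.2-fold lower number from compound 1 to compound 4 (0.08 log units; within the scatter), with hydrogen in place of chloro on an aromatic carbon, adds that removing the chloro from the aromatic group also leaves the number within the scatter. No supporting measurement is available to explain this flat result.

The compounds shown leave open whether any group on this nitrogen can move the number beyond the scatter. A carboxylic acid or an amine on the aromatic ring, or a longer chain in place of cyclohexyl, would be a sharper test of this position.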